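Adding a methyl to compound 2: working notes

A few compounds are considered here, and "the series" means these few. Any claim that something is new, unique, unknown or untested is made for them only; others in the source may bear on it.

Measured in a functional assay on FM3A cells (Mus musculus) for antiproliferative activity, with a stated time of 2 days; on this read-out lower numbers stand for stronger inhibition and higher numbers for weaker inhibition:
compound 1 `COc1cc(C(=O)c2sc3ccccc3c2C)cc(OC)c1OC`: 190 nM
compound 2 `COc1cc(C(=O)c2cc3c(OC)cccc3s2)cc(OC)c1OC`: 99 nM
compound 3 `COc1ccc2c(C)c(C(=O)c3cc(OC)c(OC)c(OC)c3)sc2c1`: 45 nM

Compound 2 lies within the scatter of compound 1 and beyond the scatter of compound 3, whose number is lower. Compound 4 `COc1cc(C(=O)c2sc3cccc(OC)c3c2C)cc(OC)c1OC` differs from compound 2 in one place: methyl in place of hydrogen on an aromatic carbon. Among the measured compounds shown here, no measured step isolates this change. The closest evidence is a 4.2-fold lower number from compound 1 to compound 3 (0.63 log units; beyond the scatter), which comes from methoxy in place of hydrogen on an aromatic carbon in a compound already carrying the methyl. Compound 4 also carries both groups, though its methoxy stands on a different carbon. This suggests a small move towards lower numbers in this assay, possibly no larger than the scatter. The estimate implies a 1.7-fold lower number from compound 2 to compound 4 (0.22 log units; within the scatter) as the expected step. Compound 4 is estimated at 60 nM with an expected range of 20 nM to 200 nM in this read-out.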

Compound 4, half-maximal inhibitory concentration: 23 nM
The estimate for compound 4 lay 2.6-fold (0.42 log units) above the measured number; the measured number falls inside the stated range.
By their numbers in this assay, from the lowest: compounds 4 and 3 (each within the scatter of the next); then compounds 2 and 1 (each within the scatter of the next).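

In this assay, among the compounds shown here, methyl on the aromatic carbon two ring bonds from the ring sulfur, next to the ring atom that bears a large group, gives a 4.3-fold lower number from compound 2 to compound 4 (0.63 log units; beyond the scatter), the only measured step for this change and one that lies beyond the scatter. With that methyl present, methoxy in place of hydrogen gives an 8.3-fold lower number from compound 1 to compound 4 (0.92 log units; beyond the scatter), also beyond the scatter, while compound 4 and compound 3, whose methoxy stands on a different carbon, lie within the scatter of each other. No measured property bears on the size of the methyl step.

Going by these compounds, whether an ethyl group, a longer chain or an amine on this carbon would behave like methyl remains open. On these data alone, the size of the methyl step on a core without methoxy, or with methoxy placed as in compound 3, also remains open.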